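Straight propyl chain replaces branched isopropyl on the amine

This account rests on a few compounds, and the source may have more. Where it says the series, first, only, none or still open, it means among the compounds named here.

Compound 1 `C=CCNC(=C\C(=O)/C=C/c1ccc(O)c(OC)c1)/C=C/c1ccc(O)c(OC)c1` and compound 2 `COc1cc(/C=C/C(=O)/C=C(/C=C/c2ccc(O)c(OC)c2)NCC(C)C)ccc1O` share one core and differ only in the group on a saturated chain carbon bound to an amine nitrogen. In a functional assay on Caco-2 cells (Homo sapiens), read by fluorescence, tested at 10 uM (on this read-out higher numbers stand for a weaker effect at the one concentration tested and lower numbers for a stronger effect), compound 1 gives 76%, and compound 2 gives 74%; the step of a number 2 percentage points lower from compound 1 to compound 2 (within the scatter) lies within the scatter. Of the two numbers shown, compound 2 stands nearest to compound 1, and the gap between them is within the scatter, so no order can be read from them.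

Compound 3 `CCCCNC(=C\C(=O)/C=C/c1ccc(O)c(OC)c1)/C=C/c1ccc(O)c(OC)c1` has not yet been measured. It differs from compound 2 in this way: propyl in place of isopropyl on a saturated chain carbon bound to an amine nitrogen. Going by the values given here, the only measured step at this place, a number 2 percentage points lower from compound 1 to compound 2 (within the scatter), was small, and because that step a number 2 percentage points lower from compound 1 to compound 2 (within the scatter) stayed within the scatter, the expectation for compound 3 is no step beyond the scatter, no change at the digits printed from compound 2 to compound 3 (within the scatter). Compound 3 is therefore estimated at 74% in this assay, with an expected range from 62% to 86%.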

Compound 3, a percentage reported as activity, at one concentration (the size of the read-out at that concentration, not a potency): 83%
The estimate for compound 3 lay 9 percentage points below the measured number; the range from low to high includes it.
By their numbers in this assay, from the lowest: compounds 2, 1 and 3 (each within the scatter of the next).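

In this assay, the straight propyl chain brings a third group to this place on a saturated chain carbon bound to an amine nitrogen, and the read-out shows a number 9 percentage points higher from compound 2 to compound 3 (within the scatter) and a number 7 percentage points higher from compound 1 to compound 3 (within the scatter) as well. Vinyl, isopropyl and propyl therefore all lie within the scatter of one another, so neither the branched against the straight chain nor the propyl against the vinyl end can be read as a change at this position. No measurement is available that could account for these numbers.

From the compounds shown here alone, whether a longer chain such as octyl, a ring such as cyclohexyl or benzyl, or a carboxylic acid at the end of the chain would move the number beyond the scatter stays open. Going by these compounds, the three compounds show only small carbon groups at this place, so how far this tolerance extends remains unknown.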